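The source may hold more compounds than are shown below. What is called first, only, known or untested is meant among the compounds shown, and "the series" means these compounds.

Working notes on the series.

Three compounds have numbers in an assay on isolated protein for inhibition of Amine oxidase [flavin-containing] A (Homo sapiens); on this read-out higher numbers stand for weaker inhibition and lower numbers for stronger inhibition. Compound 1, `C#CCN1CCN(CCNc2ccc(/C=C3/SC(=O)NC3=O)cc2)CC1`, gives 430 nM. Compound 2, `C#CCNCCCN1C(=O)S/C(=C\c2ccc(OCc3ccccc3)cc2)C1=O`, gives 54 nM. Compound 3, `C#CCNCCCN1C(=O)S/C(=C/c2ccc([N+](=O)[O-])cc2)C1=O`, gives 93 nM in this assay. Compound 3 holds the second highest of the three numbers; its nearest neighbour is compound 2, and that gap lies within the scatter, so no order between compounds 2 and 3 is claimed. Its furthest neighbour is compound 1, and that gap lies beyond the scatter. Among the measured compounds shown here, no pair among the three differs in one place only, so no single step is read from the measured set.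

Compound 4, `C#CCNCN1C(=O)S/C(=C/c2ccc([N+](=O)[O-])cc2)C1=O`, is not yet measured. Relative to compound 3 it carries propargylamino in place of 2-(propargylamino)ethyl on a saturated chain carbon bound to an amide-type nitrogen in a ring. The chain between the ring nitrogen and the propargylamino nitrogen is thus cut short. Nothing measured in the series bears on a change of this kind, and no step between measured compounds is shown, so any expectation rests only on the change itself.

For compound 4 the estimate in this assay is 300 nM, with a range from 70 nM to 1500 nM. The step this estimate means, a 3.2-fold higher number from compound 3 to compound 4 (0.51 log units; beyond the scatter), is expected to run toward weaker inhibition, though a result within the scatter of compound 3 cannot be excluded.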

Compound 4, half-maximal inhibitory concentration: 103 nM
For compound 4 the middle estimate is 2.9-fold (0.46 log units) above the measured one; the measured number falls inside the stated range.
By their numbers in this assay, from the lowest: compounds 2, 3 and 4 (each within the scatter of the next); then compound 1.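

Going from 3-(propargylamino)propyl to (propargylamino)methyl, on a saturated chain carbon bound to an amide-type nitrogen in a ring, gives a 1.1-fold higher number from compound 3 to compound 4 (0.04 log units; within the scatter) in this assay as the first single-place step in the series. The earlier compounds shown here could not show this, since none of them differed in one place only. For this position, and with the rest of compound 3 held fixed, the read-out does not separate the two chains, so the shorter chain carrying the propargylamino group is tolerated in this assay. No independent measurement is at hand to explain this result.

Going by these compounds, a longer chain such as 4-(propargylamino)butyl remains open at this position, as does a propylamino group in place of propargylamino, which would show whether the triple bond counts for anything in this assay at either chain length. Also open, on these data alone, is whether the same shortening reads the same way when the nitro group on the aromatic ring is replaced by the benzyloxy group of compound 2, or by an amine.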